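From propyl to isopentyl: how far will the number rise?

A few compounds are considered here, and "the series" means these few. Any claim that something is new, unique, unknown or untested is made for them only; others in the source may bear on it.

Within the data shown here, in a physicochemical assay for lipophilicity (a lower number here means a more polar compound, a higher number a more lipophilic compound), compound 1 `CCOC(=O)/C=C(C)/C=C/CC(C)CCCC(C)(C)OC` gives 5.54 and compound 2 `CCCOC(=O)/C=C(C)/C=C/CC(C)CCCC(C)(C)OC` gives 6.08 as the higher of the two numbers so far. Compound 3 `COC(C)(C)CCCC(C)C/C=C/C(C)=C/C(=O)OCCC(C)C` is still unmeasured and differs from compound 2 by isopropyl in place of methyl on a saturated chain carbon, two bonds along the chain from an oxygen next to a carbonyl group in a single place, with isopropyl in place of methyl on a saturated chain carbon, two bonds along the chain from an oxygen next to a carbonyl group. Among the measured compounds shown here, only one measured step bears on this, namely a number 0.54 log units higher from compound 1 to compound 2 (beyond the scatter) with methyl in place of hydrogen at that same place. As isopropyl is larger than the methyl it replaces, a further rise in this assay of somewhat greater size is expected, though one step is thin evidence. The expected step is a number 0.77 log units higher from compound 2 to compound 3 (beyond the scatter) on this single precedent. The estimate for compound 3 is 6.85 with 6.45 to 7.3 as its expected range.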

Compound 3, partition coefficient: 7.03
Compound 3: the middle estimate sits 0.18 log units below what was measured, within the range that was stated.
By their numbers in this assay, from the lowest: compound 1; then compound 2; then compound 3.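

In this assay, the place on a saturated chain carbon, two bonds along the chain from an oxygen next to a carbonyl group, now shows that the rise continues beyond a single added methyl, with isopropyl in place of methyl giving a number 0.95 log units higher from compound 2 to compound 3 (beyond the scatter) as a second step in the same direction. Over the whole series, isopropyl in place of hydrogen gives a number 1.49 log units higher from compound 1 to compound 3 (beyond the scatter) and no compound here goes against the order ethyl, propyl, isopentyl. Nothing available explains the size of either step.

Going by these compounds, whether the number keeps rising with a longer chain such as octyl, and whether a straight chain would match the branched isopentyl, stays open. What an amine or a carboxylic acid at this place would give is also unknown.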